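A few compounds are considered here, and "the series" means these few. Any claim that something is new, unique, unknown or untested is made for them only; others in the source may bear on it.

an ADME assay on cells (Fibroblast, Homo sapiens) for cytotoxicity, read by MTT assay, with a stated time of 24 h (a higher number here means a weaker inhibitor, a lower number a stronger inhibitor), gives little to work with around compound 2 (`COc1ccc(N(CC(=O)NCCCSc2ccccc2)C(=O)/C=C/c2ccccc2)cc1`). Compound 2 gives >= 100000 nM, which is a limit and not a number. Compound 3 (`COc1ccc(N(CC(=O)NCCC[Se]c2ccccc2)C(=O)/C=C/c2ccccc2)cc1`) gives >= 100000 nM, which is also a limit. These two compounds stand at the limit of >= 100000 nM in this assay, at which 2 of the 3 values shown sit.

Compound 4 (`COc1ccc(N(CC(=O)NCCCSc2ccccc2)C(=O)CNC(=O)OC(C)(C)C)cc1`) departs from compound 2 at one place: ((tert-butoxycarbonyl)amino)methyl in place of 2-phenylethenyl on a carbonyl carbon. In words, ((tert-butoxycarbonyl)amino)methyl stands in place of 2-phenylethenyl on a carbonyl carbon.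

Within the data shown here, the only measured step is a step that the two limits leave unreadable from compound 2 to compound 3. It has no readable size and involves a different place in the molecule, so it cannot be carried over to this change. Among the measured compounds shown here, the only number in this assay comes from compound 1 (`COc1ccc(N(CC(=O)NCCC[Te]c2ccccc2)C(=O)CNC(=O)OC(C)(C)C)cc1`), which gives 25000 nM and also carries ((tert-butoxycarbonyl)amino)methyl on a carbonyl carbon. For the measured compounds named here, no measured step connects compound 1 to compound 4, so that value serves only as a cautious pull towards stronger inhibition.

Compound 4 is therefore expected to stay close to the top of the measurable range, and a report of only a limit is likely. The estimate is an at least 1.2-fold lower number from compound 2 to compound 4 (0.09 log units; that floor lies within the scatter), a modest move at most towards stronger inhibition. For compound 4 the estimated value is 80000 nM, with an expected range from 30000 nM to 150000 nM.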

Compound 4, half-maximal inhibitory concentration: >= 100000 nM
Compound 4 was reported as a limit; the forecaster's own chance of this, stated with the estimate: 65%; middle value at least 1.2-fold (0.09 log units) from the limit.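

In this assay, ((tert-butoxycarbonyl)amino)methyl in place of 2-phenylethenyl on the carbonyl carbon leaves compound 4 at a limit of the assay, as compound 2 is, so this step and any other step between two limits cannot be read: the limit of >= 100000 nM in this assay, at which 3 of the 4 values shown sit.

Among these compounds, with ((tert-butoxycarbonyl)amino)methyl held in place, the sulfur-bearing group in place of the tellurium-bearing group gives the one readable step, an at least 4.0-fold higher number from compound 1 to compound 4 (0.60 log units; beyond the scatter). In this pair the measurable value therefore goes with the tellurium-bearing group of compound 1, and ((tert-butoxycarbonyl)amino)methyl on the carbonyl carbon does not by itself bring compound 4 to a measurable number.

As far as these compounds go, whether 2-phenylethenyl on the carbonyl carbon would also give a measurable number alongside the tellurium-bearing group stays open, so the change at this position still has no readable size. Also open, from the compounds shown here alone, is how an aminomethyl group or a longer chain on that carbonyl carbon would read, with either the tellurium-bearing group or the sulfur-bearing group on the other side of the molecule.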